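Dichloroindole ribosides: carbamoyl replaced by a dimethylhydrazone

A few compounds are considered here, and "the series" means these few. Any claim that something is new, unique, unknown or untested is made for them only; others in the source may bear on it.

Going by the values given here, compound 2 `NC(=O)c1c(Cl)n(C2O[C@H](CO)[C@@H](O)[C@H]2O)c2cc(Cl)c(Cl)cc12` holds the only number in the set: in a functional assay on KB cells (Homo sapiens) for cytotoxicity, read by spectrophotometry and crystal violet staining (a higher number here means a weaker inhibitor, a lower number a stronger inhibitor), compound 2 gives 45000 nM. Compound 1 `NC(=O)N/N=C/c1c(Cl)n(C2O[C@H](CO)[C@@H](O)[C@H]2O)c2cc(Cl)c(Cl)cc12` reports only a limit, > 100000 nM. Compound 3 `OC[C@H]1O[C@@H](n2c(Br)nc3cc(Cl)c(Cl)cc32)[C@H](O)[C@@H]1O` likewise reports only a limit, > 100000 nM. Among the compounds with values here, the one measured step, an at least 2.2-fold lower number from compound 1 to compound 2 (0.34 log units; beyond the scatter), runs from a hydrazone-type group to the carbamoyl group and is bounded by the limit of > 100000 nM in this assay, at which 2 of the 3 values shown sit. Compound 4 `CN(C)/N=C/c1c(Cl)n(C2O[C@H](CO)[C@@H](O)[C@H]2O)c2cc(Cl)c(Cl)cc12` reverses that direction: a group of 5 heavy atoms (3 carbon, 2 nitrogen; no ring) in place of a group of 3 heavy atoms (1 carbon, 1 nitrogen, 1 oxygen; no ring), on an aromatic carbon. Within the data shown here, no measured step covers this exact change; the nearest, from compound 1 to compound 2, argues that moving away from the carbamoyl group loses activity. A step of a 2.0-fold higher number from compound 2 to compound 4 (0.30 log units; within the scatter) is therefore expected, and compound 4 is estimated at 90000 nM, within 30000 nM to 300000 nM, with a real chance of a limit only.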

Compound 4, half-maximal inhibitory concentration: 70000 nM
Beside the measured number, compound 4's estimate is 1.3-fold (0.11 log units) above it; measured number inside the range.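

In this assay, a group other than carbamoyl on this aromatic carbon now has a number, and it does not separate from carbamoyl: a 1.6-fold higher number from compound 2 to compound 4 (0.19 log units; within the scatter), so compound 2 and compound 4 cannot be told apart despite 0 hydrogen-bond donors in the entering group. Dimethylamino in place of ureido on the double-bonded nitrogen gives an at least 1.4-fold lower number from compound 1 to compound 4 (0.15 log units; that floor lies within the scatter), so no difference between these two groups is established. Compound 1 is held by a limit and not a number: the limit of > 100000 nM in this assay, at which 2 of the 4 values shown sit.

From the compounds shown here alone, whether a carboxylic acid, a primary amine or a longer alkyl chain on this carbon would separate from carbamoyl remains open. Going by these compounds, the true distance between ureido and dimethylamino also remains open.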